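Solubility at the Assay Ceiling: Piperazine Gives Way to Piperidine

The source may hold more compounds than are shown below. What is called first, only, known or untested is meant among the compounds shown, and "the series" means these compounds.

Compound 3 `CC(=O)N1CCN(C(=O)N2Cc3c(NC(=O)c4ccc(F)cc4)n[nH]c3C2(C)C)CC1` is measured in a physicochemical assay for solubility, at pH 7 (a lower number here means a less soluble compound, a higher number a more soluble compound), only as a limit, > 225000 nM. Compound 1 `CC1(C)c2[nH]nc(NC(=O)c3ccc(F)cc3)c2CN1C(=O)C1CCN(C2CC2)CC1` likewise reaches only a limit in this assay, > 225000 nM. Compound 2 `CN1CCC(C(=O)N2Cc3c(NC(=O)Nc4cccc(F)c4)n[nH]c3C2(C)C)CC1` also returns a limit in this assay, > 225000 nM. Going by the values given here, the one single-point step, a step that the two limits leave unreadable from compound 1 to compound 3, cannot be read because the limit of > 225000 nM in this assay, at which 3 of the 3 values shown sit, hides its size. Compound 4 `CCN1CCC(C(=O)N2Cc3c(NC(=O)c4ccc(F)cc4)n[nH]c3C2(C)C)CC1` differs from compound 3 by 1-ethylpiperidin-4-yl in place of 4-acetylpiperazin-1-yl on a carbonyl carbon. Among the compounds with values here, no measured step bears readably on this change, and with every compound at the limit of > 225000 nM in this assay, at which 3 of the 3 values shown sit, no step beyond the scatter is expected in this assay. Compound 4 is therefore expected to sit at or past the limit, estimated at 300000 nM with a range from 150000 nM to 600000 nM. This estimate means an expected step that the limit leaves unreadable from compound 3 to compound 4.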

Compound 4, solubility: > 225000 nM
Compound 4: no number, only a limit (the forecaster's own chance of this, stated with the estimate: 85%); the middle value does not contradict the limit.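

Going by these compounds alone, compound 4 returns only a limit in this assay and no step to compound 4 from compound 3 or compound 1 can be read: the limit of > 225000 nM in this assay, at which 4 of the 4 values shown sit. In this assay the compounds shown leave open whether 1-ethylpiperidin-4-yl and 4-acetylpiperazin-1-yl, or ethyl and cyclopropyl, differ at all.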